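This account rests on a few compounds, and the source may have more. Where it says the series, first, only, none or still open, it means among the compounds named here.

Measured so far:
- compound 1, `CCC1C(=O)N(CCCCCCCOc2ccc(Cl)cc2)/C(=N\C#N)N1c1ccncc1`, 3450 nM
- compound 2, `N#C/N=C1\N(CCCCCOc2ccc(Cl)cc2)C(=O)C(c2ccccc2)N1c1ccncc1`, 415 nM
- compound 3, `N#C/N=C1\N(CCCCCCOc2ccc(Cl)cc2)C(=O)C(c2ccccc2)N1c1ccncc1`, 44 nM

In a functional assay on HepG2 cells (Homo sapiens) for cytotoxicity (a lower number here means a stronger inhibitor, a higher number a weaker inhibitor), compound 3 gives the lowest number of the three, the nearest being compound 2 and the furthest compound 1, both beyond the scatter. The step to compound 4, `N#C/N=C1\N(CCCCCCCOc2ccc(Cl)cc2)C(=O)C(c2ccccc2)N1c1ccncc1`, is a lengthening of the linking chain: (4-chlorophenoxy)methyl in place of 4-chlorophenoxy on a saturated chain carbon, six bonds along the chain from an amide-type nitrogen in a ring. Among the compounds with values here, only one measured step bears on it directly, the step one bond shorter along the same chain, a 9.4-fold lower number from compound 2 to compound 3 (0.97 log units; beyond the scatter), which came out as a clear gain. Compound 1 carries the same longer chain as compound 4 but differs from it in a second place as well, so its value shows only that such a chain can sit in a weakly active compound, not what the chain itself does. With a single supporting step, the expectation is that compound 4 lies at or somewhat below compound 3, the step of a 1.8-fold lower number from compound 3 to compound 4 (0.25 log units; within the scatter) being expected, though possibly no larger than the scatter. Compound 4 is therefore estimated at 25 nM, within 6 nM to 120 nM.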

Compound 4, half-maximal inhibitory concentration: 380 nM
The estimate for compound 4 lay 15-fold (1.18 log units) below the measured number, outside the stated range (above it).
By their numbers in this assay, from the lowest: compound 3; then compounds 4 and 2 (each within the scatter of the next); then compound 1.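

In this assay the gain from lengthening the chain does not continue: a 9.4-fold lower number from compound 2 to compound 3 (0.97 log units; beyond the scatter) is followed by an 8.6-fold higher number from compound 3 to compound 4 (0.94 log units; beyond the scatter) and the number climbs back, so among these three phenyl compounds the chain of compound 3 gives a clear minimum rather than the start of a trend. The chains on either side of it end up level, with a 1.1-fold lower number from compound 2 to compound 4 (0.04 log units; within the scatter) as the whole difference. With the longer chain held fixed, the other group matters too: phenyl in place of ethyl on a saturated ring carbon gives a 9.1-fold lower number from compound 1 to compound 4 (0.96 log units; beyond the scatter) as a separate effect.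

No measurement shown here explains why the number rises again at this chain length. Still open, as far as these compounds go, are how a longer chain would behave, and whether ethyl on the chain of compound 3 would show the same minimum.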